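Chain lengthening and cytotoxicity in a nucleoside series

The source may report more compounds than this note shows. Statements on the series, on what has been measured and on what is new or still open speak of the compounds shown alone.

compound 1 `CC/C=C/c1cccc(-c2cc3cn([C@H]4C[C@H](O)[C@@H](CO)O4)c(=O)nc3o2)c1`: 68000 nM
compound 2 `CC/C=C/c1ccc(-c2cc3cn([C@H]4C[C@H](O)[C@@H](CO)O4)c(=O)nc3o2)cc1`: > 200000 nM
compound 3 `CCC/C=C/c1cccc(-c2cc3cn([C@H]4C[C@H](O)[C@@H](CO)O4)c(=O)nc3o2)c1`: > 200000 nM

In an ADME assay on HEL cells (Homo sapiens) for cytotoxicity (on this read-out higher numbers stand for lower toxicity in this test and lower numbers for higher toxicity in this test), compound 1 gives 68000 nM. Compound 3 gives only a limit of the assay, > 200000 nM. Compound 2 likewise gives only a limit, > 200000 nM. The change from compound 1 to compound 3 is methyl in place of hydrogen on a saturated chain carbon, two bonds along the chain from a double-bonded chain carbon, and it made a step of an at least 2.9-fold higher number from compound 1 to compound 3 (0.46 log units; beyond the scatter). Compounds 1 and 2 are built from the same atoms joined differently; how their two cores differ is not broken down here. Compound 4 `CCC/C=C/c1ccc(-c2cc3cn([C@H]4C[C@H](O)[C@@H](CO)O4)c(=O)nc3o2)cc1` is not yet measured and differs from compound 2 by methyl in place of hydrogen on a saturated chain carbon, two bonds along the chain from a double-bonded chain carbon, the same change. Because compound 2 already sits at the limit of > 200000 nM in this assay, at which 2 of the 3 values shown sit, compound 4 is expected to stay at that limit, an expected step that the limit leaves unreadable from compound 2 to compound 4 in this assay. Compound 4 is estimated at 250000 nM.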

Compound 4, half-maximal cytotoxic concentration: > 200000 nM
Compound 4: a limit, no number; the forecaster's own chance of this, stated with the estimate: 80%; the middle value is on the limit's open side.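

The step from compound 2 to compound 4 cannot be read, because both give only a limit in this assay, not a number: the limit of > 200000 nM in this assay, at which 3 of the 4 values shown sit.

The compounds shown leave open whether going from but-1-en-1-yl to pent-1-en-1-yl changes cytotoxicity at all in compound 4.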